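This account rests on a few compounds, and the source may have more. Where it says the series, first, only, none or still open, it means among the compounds named here.

Working notes on the series. Of the compounds shown here, three of the shared core have been measured in a functional assay on HepG2 cells (Homo sapiens) for cytotoxicity, read by MTT assay, with a stated time of 48 h (on this read-out lower numbers stand for stronger inhibition and higher numbers for weaker inhibition), and all three return only the limit of the assay. Compound 1 `CCCc1nnc(SCC(=O)c2ccc(C)cc2)n1N1C(=O)c2ccccc2C1=O` gives > 200000 nM, which is a limit and not a number. Compound 2 `C=CCSc1nnc(-c2cc(OC)c(OC)c(OC)c2)n1N1C(=O)c2ccccc2C1=O` gives > 200000 nM, likewise a limit. Compound 3 `C#CCSc1nnc(-c2cc(OC)c(OC)c(OC)c2)n1N1C(=O)c2ccccc2C1=O` gives > 200000 nM, again a limit. Compound 3 thus stands at the limit alongside the other two, with no number that would set it apart, as summed up by the limit of > 200000 nM in this assay, at which 3 of the 3 values shown sit. For the measured compounds named here, the only single-point step that can be drawn within the measured set, a step that the two limits leave unreadable from compound 2 to compound 3, is left unreadable by the two limits at its ends.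

Compound 4 `COc1cc(-c2nnc(SCC(=O)c3ccc(C)cc3)n2N2C(=O)c3ccccc3C2=O)cc(OC)c1OC` is the next member due in this assay. It differs from compound 3 in one place: (4-methylphenyl)carbonyl in place of ethynyl on a saturated chain carbon bound to a sulfur. Going by the values given here, no measured step covers this exchange; the one step available is unreadable. Among the compounds with values here, the entering group is the one already carried by compound 1, whose value in this assay, > 200000 nM, is a limit. On that basis no movement beyond the scatter is expected from compound 3 to compound 4, and the step that the limit leaves unreadable from compound 3 to compound 4 is estimated to be flat, most probably ending again at a limit. Compound 4 is therefore expected to read 300000 nM in this assay, within 100000 nM to 1000000 nM.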

Compound 4, half-maximal inhibitory concentration: 9440 nM
Compound 4: middle estimate off by 32-fold (1.50 log units), on the high side; measured number outside the range, below it.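

In this assay, for the compounds shown here, the group on the saturated chain carbon bound to a sulfur now proves able to move the read-out, which the earlier compounds could not show: with 3,4,5-trimethoxyphenyl held, (4-methylphenyl)carbonyl in place of ethynyl gives an at least 21-fold lower number from compound 3 to compound 4 (1.32 log units; beyond the scatter), and in place of vinyl it gives an at least 21-fold lower number from compound 2 to compound 4 (1.32 log units; beyond the scatter). The group on the aromatic carbon also counts, since with (((4-methylphenyl)carbonyl)methyl)sulfanyl held, 3,4,5-trimethoxyphenyl in place of propyl gives an at least 21-fold lower number from compound 1 to compound 4 (1.32 log units; beyond the scatter). Neither group alone lifts a compound off the limit in the compounds shown, and only compound 4, which carries both, returns a number, while the others remain at a limit and not at a number: the limit of > 200000 nM in this assay, at which 3 of the 4 values shown sit.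

On these data alone, the full size of all three steps stays open, as each has a limit at one end, and so does whether the carbonyl or the 4-methylphenyl ring carries the change. Also open, as far as these compounds go, is how an amine or a carboxylic acid on the saturated chain carbon bound to a sulfur, or a longer chain in place of propyl, would read in this assay.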